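This account rests on a few compounds, and the source may have more. Where it says the series, first, only, none or still open, it means among the compounds named here.

Measured in a functional assay on HCT-116 cells (Homo sapiens) for cytotoxicity, read by MTT assay; a higher number here means a weaker inhibitor, a lower number a stronger inhibitor:
- compound 1 `C=C1C(=O)O[C@H]([C@@H]2C(=O)C=C[C@]2(C)O)[C@H]1CCC(C)=O` gives 3300 nM
- compound 2 `C=C1C(=O)O[C@H]([C@@H]2C(=O)C=C[C@@]2(C)O)[C@H]1CCC(C)=O` gives 6000 nM
- compound 3 `C=C1C(=O)O[C@H](C2=C(C)[C@@H](O)CC2=O)[C@H]1CCC(C)=O` gives 13000 nM

Compound 2 stands second highest of the three numbers. Its nearest neighbour is compound 1, within the scatter; compound 3 stands furthest from it, a gap beyond the scatter. For the measured compounds named here, the one measured step, a 1.8-fold higher number from compound 1 to compound 2 (0.26 log units; within the scatter), rests on (the fact that compounds 1 and 2 differ only in the configuration as drawn).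

Compound 4 `C=C1C(=O)O[C@H]([C@H]2C(=O)C=C[C@@]2(C)O)[C@H]1CCC(C)=O` differs from compound 2 thus: the two compounds have the same atoms and bonds and differ only in configuration as drawn: 1 of 4 stereo elements differ; a stereocentre at a saturated ring carbon is drawn S in compound 2 and R in compound 4. Going by the values given here, the only measured step that bears on it is a 1.8-fold higher number from compound 1 to compound 2 (0.26 log units; within the scatter), which likewise turned on configuration alone and stayed within the scatter. No step beyond the scatter is therefore expected in this assay in either direction. Compound 4 is estimated at 6000 nM, within a range of 2500 nM to 14000 nM. The expected step is no change at the digits printed from compound 2 to compound 4 (within the scatter).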

Compound 4, half-maximal inhibitory concentration: 6000 nM
Beside the measured number, compound 4's estimate shows no gap at the digits printed, and the stated range covers the measured number.
By their numbers in this assay, from the lowest: compounds 1, 2 and 4 (each within the scatter of the next); then compound 3.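

In this assay, this second stereocentre at a saturated ring carbon gives no change at the digits printed from compound 2 to compound 4 (within the scatter), so inverting it leaves the number within the scatter, as the earlier step did at the other stereocentre. Changing both stereocentres together gives a 1.8-fold higher number from compound 1 to compound 4 (0.26 log units; within the scatter), which also stays within the scatter. These readings concern configuration alone: (the fact that compounds 1 and 4 differ only in the configuration as drawn) .

The other two stereo elements remain untested by any step shown here. Also open, going by these compounds, is how an amine or a carboxylic acid on the shared core would shift the number in this assay.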